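Methylsulfonyl for Methyl on a Triazole Antagonist

A few compounds are considered here, and "the series" means these few. Any claim that something is new, unique, unknown or untested is made for them only; others in the source may bear on it.

Two compounds in this series share a core carrying a dichlorophenyl ring. Compound 1 `Cc1ccccc1Nc1ncnn1-c1cccc(Cl)c1Cl` and compound 2 `Cc1ccccc1CNc1ncnn1-c1cccc(Cl)c1Cl` were tested in a functional assay for antagonist activity at P2X purinoceptor 7 (Homo sapiens), read by FLIPR and calcium flux; a higher number here means a weaker inhibitor, a lower number a stronger inhibitor. Compound 1 gives 17.8 nM. Compound 2 gives 20.9 nM, the higher of the two numbers, though the gap to compound 1 lies within the scatter of repeated measurements, so neither can be called the stronger inhibitor.

Compound 3 `CS(=O)(=O)c1ccccc1CNc1ncnn1-c1cccc(Cl)c1Cl` has not yet been measured in this assay. It differs from compound 2 in one place: methylsulfonyl in place of methyl on an aromatic carbon. Among the measured compounds shown here, no step between measured compounds speaks to this kind of change, so the expectation rests on the structural change alone. A modest weakening is expected, in the direction of a higher number, of a size that may sit at the edge of the scatter. For compound 3 the expected step is a 1.9-fold higher number from compound 2 to compound 3 (0.28 log units; within the scatter). Compound 3 is therefore estimated at 40 nM, with a range from 10 nM to 160 nM.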

Compound 3, half-maximal inhibitory concentration: 20 nM
Compound 3: the middle estimate sits 2.0-fold (0.30 log units) above what was measured; measured number inside the range.
By their numbers in this assay, from the lowest: compounds 1, 3 and 2 (each within the scatter of the next).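

In this assay, methylsulfonyl in place of methyl on an aromatic carbon, ortho to a large group, gives a 1.0-fold lower number from compound 2 to compound 3 (0.02 log units; within the scatter). The earlier compounds shown here both carried methyl at this place and so could not show how the number responds to a change of group there; this step shows that a group with hydrogen-bond acceptors, where methyl has none, can stand on this carbon with the number staying within the scatter. Nothing available explains why the number holds at this position.

The compounds shown leave open whether an amine, a carboxylic acid or a longer alkyl chain on this carbon would also stay within the scatter. They also leave open whether methylsulfonyl in place of methyl would read the same on compound 1.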